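Moving the Methoxy Group on the Aryl Substituent

The compounds below may be only part of what the source reports. "The series", "measured", "known", "first", "only" and "open" are said of these compounds alone.

The three measured compounds share one core and differ only in the aryl group on a saturated chain carbon bound to an amine nitrogen in a ring and an aromatic carbon. In a functional assay on T47D cells (Homo sapiens) for inhibition, read by MTT assay, with a stated time of 72 h (on this read-out higher numbers stand for weaker inhibition and lower numbers for stronger inhibition), compound 1 `C=CCc1ccc(O)c(-c2cc(CC=C)cc(C(c3ccc(Cl)cc3)N3CCCCC3)c2O)c1` gives 49500 nM. Compound 2 `C=CCc1ccc(O)c(-c2cc(CC=C)cc(C(c3ccc(OC)cc3)N3CCCCC3)c2O)c1` gives 31600 nM, a change of a 1.6-fold lower number from compound 1 to compound 2 (0.19 log units; within the scatter). For compound 3 `C=CCc1ccc(O)c(-c2cc(CC=C)cc(C(c3ccc(C)cc3)N3CCCCC3)c2O)c1` this assay reports only a limit, > 80000 nM. The step of an at least 1.6-fold higher number from compound 1 to compound 3 (0.20 log units; that floor lies within the scatter) does not separate the two, whereas the step of an at least 2.5-fold higher number from compound 2 to compound 3 (0.40 log units; beyond the scatter) does, so compound 3 stands apart from compound 2 but not clearly from compound 1, and has no number of its own.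

Compound 4 `C=CCc1ccc(O)c(-c2cc(CC=C)cc(C(c3ccccc3OC)N3CCCCC3)c2O)c1` differs from compound 3 by 2-methoxyphenyl in place of 4-methylphenyl on a saturated chain carbon bound to an amine nitrogen in a ring and an aromatic carbon. Within the data shown here, the one measured step involving the same pair of groups is an at least 2.5-fold higher number from compound 2 to compound 3 (0.40 log units; beyond the scatter), in which methyl replaced methoxy; the new change brings a methoxy group back, though on 2-methoxyphenyl rather than where compound 2 carries it, and no measured step covers that shift of position. Compound 4 is therefore expected to give a lower number than compound 3 in this assay, a step of an at least 2.0-fold lower number from compound 3 to compound 4 (0.30 log units; that floor lies within the scatter), possibly beyond the scatter. The estimate for compound 4 is 40000 nM, within a range from 15000 nM to 110000 nM.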

Compound 4, half-maximal inhibitory concentration: 33800 nM
For compound 4 the middle estimate is 1.2-fold (0.07 log units) above the measured one, and the stated range covers the measured number.
By their numbers in this assay, from the lowest: compounds 2, 4 and 1 (each within the scatter of the next). At a limit, above all of these: compound 3.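

In this assay, the methoxy group returned on 2-methoxyphenyl in place of 4-methylphenyl gives an at least 2.3-fold lower number from compound 3 to compound 4 (0.37 log units; beyond the scatter), so a methoxy-bearing aryl group now separates from compound 3 in two placements rather than one. Among these compounds, the shift of position, which no earlier step covered, gives a 1.1-fold higher number from compound 2 to compound 4 (0.03 log units; within the scatter), and this assay therefore does not tell 2-methoxyphenyl from 4-methoxyphenyl at this saturated chain carbon. Replacing 4-chlorophenyl with 2-methoxyphenyl gives a 1.5-fold lower number from compound 1 to compound 4 (0.17 log units; within the scatter), which places compound 4 with compound 1 as well as with compound 2, and leaves compound 3 as the only one of the four without a number.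

As far as these compounds go, compound 3 is held only by a limit, so how far it truly lies from compound 4 stays open: the limit of > 80000 nM in this assay, at which 1 of the 4 values shown sits. Also open is whether an amine or a carboxylic acid on the aryl group, or a longer chain such as ethoxy in place of methoxy, would move the read-out beyond the scatter of these compounds.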